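Stereoisomers of a hydroxylated pipecolic acid core against cytosolic ENGase

The source may hold more compounds than are shown below. What is called first, only, known or untested is meant among the compounds shown, and "the series" means these compounds.

Measured compounds:
compound 1, `O=C(O)[C@H]1NC[C@H](O)[C@H](O)[C@H]1O`, 7.6%
compound 2, `O=C(O)[C@H]1NC[C@H](O)[C@@H](O)[C@@H]1O`, 43%

Among the compounds with values here, in an assay on isolated protein for inhibition of cytosolic endo-beta-N-acetylglucosaminidase (Homo sapiens), tested at 1000 uM (a lower number here means less inhibition, a higher number more inhibition at the concentration tested (going by the name of the read-out)), compound 2 gives 43%, the highest of the two numbers so far; the nearest is compound 1, whose value in this assay is 7.6%. Within the data shown here, the one measured step, a number 35.4 percentage points higher from compound 1 to compound 2 (beyond the scatter), is large and beyond the scatter, and it rests on (the fact that compounds 1 and 2 differ only in the configuration as drawn), so the series already shows that configuration alone at the shared core can move inhibition substantially.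

Compound 3, `O=C(O)[C@@H]1NC[C@@H](O)[C@@H](O)[C@H]1O`, is not yet measured. Relative to compound 2 the change is the two compounds have the same atoms and bonds and differ only in configuration as drawn: 3 of 4 stereo elements differ; a stereocentre at a saturated ring carbon is drawn S in compound 2 and R in compound 3; a stereocentre at a saturated ring carbon is drawn S in compound 2 and R in compound 3; a stereocentre at a saturated ring carbon is drawn R in compound 2 and S in compound 3. Among the measured compounds shown here, only the step from compound 1 to compound 2 bears on this, and it shows that flipping two ring stereocentres shifted inhibition by a large amount in one direction. Flipping three stereocentres leaves the direction open; the two measured values bracket the range seen so far, and compound 3 is expected to fall nearer the lower of them, with a step of a number 28 percentage points lower from compound 2 to compound 3 (beyond the scatter) expected. Compound 3 is estimated at 15%, within 0% to 45%.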

Compound 3, a percentage reported as inhibition, at one concentration (the size of the read-out at that concentration, not a potency): 26%
Compound 3: middle estimate off by 11 percentage points, on the low side; measured number inside the range.
By their numbers in this assay, from the lowest: compound 1; then compound 3; then compound 2.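

In this assay, within the data shown here, the new steps are a number 17 percentage points lower from compound 2 to compound 3 (beyond the scatter) and a number 18.4 percentage points higher from compound 1 to compound 3 (beyond the scatter), both modest, so compound 3 is separated from each of the other two compounds and compound 1 is no longer the only comparison for compound 2. The step with three differing stereo elements, from compound 1 to compound 3, is modest, while a number 35.4 percentage points higher from compound 1 to compound 2 (beyond the scatter) is large with only two differing, so among these three compounds the size of a step does not follow the count of changed stereocentres. Both new steps rest on configuration alone: the fact that compounds 1 and 3 differ only in the configuration as drawn and the fact that compounds 2 and 3 differ only in the configuration as drawn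

No pair among these compounds differs at a single stereocentre, so the contribution of each centre to inhibition cannot be separated, and the remaining stereoisomers of the shared core are open. From the compounds shown here alone, whether any of these configurations would hold its inhibition with an amide or a methyl ester in place of the carboxylic acid, or with a longer chain on the ring nitrogen, also remains open.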